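Working notes on the step from compound 3 to compound 4

A few compounds are considered here, and "the series" means these few. Any claim that something is new, unique, unknown or untested is made for them only; others in the source may bear on it.

Measured so far:
compound 1 `CN1CCC(CNS(=O)(=O)c2ccccc2Nc2cc(-c3ccc4ccn(C)c4c3)c3nccnc3c2)C1` gives 4640 nM in an assay on lysate for inhibition of 6-phosphofructo-2-kinase/fructose-2,6-bisphosphatase 3 (Homo sapiens), with stated times of 0.5 min and 45 min; a higher number here means a weaker inhibitor, a lower number a stronger inhibitor.
compound 2 `Cn1cc(CNS(=O)(=O)c2ccccc2Nc2cc(-c3ccc4ccn(C)c4c3)c3nccnc3c2)cn1` reaches only the assay limit > 100000 nM.
compound 3 `Cn1ccc2ccc(-c3cc(Nc4cnccc4C(=O)NCc4cncnc4)cc4nccnc34)cc21` gives 49500 nM.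

Compound 3 thus stands highest of the two numbers shown in this assay; compound 1 is the nearest, with a lower number beyond the scatter.

Compound 4 `CC(=O)N1CC(NC(=O)c2ccncc2Nc2cc(-c3ccc4ccn(C)c4c3)c3nccnc3c2)C1` differs from compound 3 in one place: 1-acetylazetidin-3-yl in place of (pyrimidin-5-yl)methyl on an amide-type nitrogen. Among the compounds with values here, the only measured step, an at least 21-fold higher number from compound 1 to compound 2 (1.33 log units; beyond the scatter), sits on the sulfonamide-linked pair and runs from 1-methylpyrrolidin-3-yl to 1-methyl-1H-pyrazol-4-yl, the reverse sense of the present change, so it gives a loose guide at best. A modest lowering of the number is expected, a 2.0-fold lower number from compound 3 to compound 4 (0.30 log units; within the scatter), possibly within the scatter. Compound 4 is estimated at 25000 nM, range 7000 nM to 100000 nM.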

Compound 4, half-maximal inhibitory concentration: 97400 nM
Compound 4: middle estimate off by 3.9-fold (0.59 log units), on the low side; low and high end bracket the measured number.
By their numbers in this assay, from the lowest: compound 1; then compounds 3 and 4 (each within the scatter of the next). At a limit, above all of these: compound 2.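

On the amide-type nitrogen, 1-acetylazetidin-3-yl in place of (pyrimidin-5-yl)methyl gives a 2.0-fold higher number from compound 3 to compound 4 (0.29 log units; within the scatter) in this assay, so at this place a six-membered aromatic ring and an acetylated four-membered non-aromatic ring cannot be told apart. Within the data shown here, this differs in size from the only earlier step, on the sulfonamide-linked pair: an at least 21-fold higher number from compound 1 to compound 2 (1.33 log units; beyond the scatter). Both amide compounds read toward the top of the assay's range, which leaves little room to size any further rise: the limit of > 100000 nM in this assay, at which 1 of the 4 values shown sits.

Open, going by these compounds, is whether a primary amine or a carboxylic acid on this amide-type nitrogen would lower the number beyond the scatter.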